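The source may report more compounds than this note shows. Statements on the series, on what has been measured and on what is new or still open speak of the compounds shown alone.

Measured in a functional assay on HL-60 cells (Homo sapiens) for inhibition (on this read-out higher numbers stand for weaker inhibition of growth and lower numbers for stronger inhibition of growth), so far:

- compound 1 `C=C(C)C(=O)c1ccc(OCc2nc(-c3ccccc3)no2)cc1C` gives 6700 nM
- compound 2 `C=C(C)C(=O)c1ccc(OCc2nc(-c3ccc(C(F)(F)F)cc3)no2)cc1C` gives 3200 nM
- compound 3 `C=C(C)C(=O)c1ccc(OCc2nc(-c3ccccc3)no2)c(C)c1C` gives 3500 nM

Compound 3 lies within the usual scatter of both compound 1 and compound 2, so it cannot be placed clearly apart from either.

The next compound, compound 4 `C=C(C)C(=O)c1ccc(OCc2nc(-c3ccc([N+](=O)[O-])cc3)no2)c(C)c1C`, is made from compound 3 by the change phenyl to 4-nitrophenyl, with nitro in place of hydrogen on an aromatic carbon in the same read-out.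

The closest guide is a 2.1-fold lower number from compound 1 to compound 2 (0.32 log units; beyond the scatter), a modest step in which trifluoromethyl replaces hydrogen on an aromatic carbon. The methyl change, a 1.9-fold lower number from compound 1 to compound 3 (0.28 log units; within the scatter), is already built into compound 3 and stays within the scatter. For the measured compounds named here, no measured compound carries nitro, so the guide is only indirect. A similar modest move toward a lower number is therefore expected, and it may not clear the scatter.

The estimated change is a 1.8-fold lower number from compound 3 to compound 4 (0.24 log units; within the scatter) in this assay overall. Compound 4 is expected near 2000 nM, with an estimated range from 900 nM to 4500 nM.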

Compound 4, concentration for 50% growth inhibition: 2400 nM
Estimate against measurement, compound 4: 1.2-fold (0.08 log units) below; measured number inside the range.
By their numbers in this assay, from the lowest: compounds 4, 2, 3 and 1 (each within the scatter of the next, the first and the last beyond it).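

In this assay, placing nitro on an aromatic carbon para to a large group gives a 1.5-fold lower number from compound 3 to compound 4 (0.16 log units; within the scatter), so this change cannot be told apart from repeat-measurement variation. Until now, the only change shown at this position was trifluoromethyl, with a 2.1-fold lower number from compound 1 to compound 2 (0.32 log units; beyond the scatter), on a core carrying one methyl fewer; the two steps point the same way, but only that one clears the scatter, so a second group at this position has not firmly established an effect. Nothing measured here explains either step.

The compounds shown leave open whether an amine or a carboxylic acid at this position would give a step beyond the scatter. They also leave open how nitro would behave on the core of compound 1, which has one methyl fewer.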